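The source may hold more compounds than are shown below. What is called first, only, known or untested is meant among the compounds shown, and "the series" means these compounds.

For the measured compounds named here, compound 1, `Cc1ccc(=O)n(CCC#N)n1`, is one of two compounds measured in a functional assay on the whole organism (stomach) for inhibition, with Rattus norvegicus as the target, at a dose of 100 mg/kg by the intraduodenal route (on this read-out higher numbers stand for more inhibition at the one dose given (going by the name of the read-out) and lower numbers for less inhibition), where compound 1 gives 0.2%. The other, compound 2, `N=C(S)CCn1[nH]c(=O)ccc1=O`, gives -13.4% in this assay, so compound 1 stands highest of the two, and the gap between them lies beyond the usual scatter. Compound 3, `Cc1ccc(=O)n(CCC(N)=O)n1`, has not yet been measured; it differs from compound 1 in one place: carbamoyl in place of cyano on a saturated chain carbon, two bonds along the chain from an aromatic nitrogen. Going by the values given here, no measured pair shows this change, so no step beyond the scatter is expected, and the estimated step is a number 1.8 percentage points higher from compound 1 to compound 3 (within the scatter). Compound 3 is accordingly expected to give about 2%, between -12% and 16%.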

Compound 3, a percentage reported as inhibition, in the whole organism at one dose (the size of the read-out at that dose, not a potency): -2.9%
Compound 3: middle estimate off by 4.9 percentage points, on the high side, and the stated range covers the measured number.
By their numbers in this assay, from the lowest: compound 2; then compounds 3 and 1 (each within the scatter of the next).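

Carbamoyl in place of cyano on a saturated chain carbon, two bonds along the chain from an aromatic nitrogen, now has a direct reading in this assay (a number 3.1 percentage points lower from compound 1 to compound 3 (within the scatter)). At this one dose, the exchange, which adds a hydrogen-bond donor, gives no difference that stands clear of the scatter. Nothing available here bears on why. Still open, going by these compounds, is whether a carboxylic acid or an amine in this place, or a longer chain, would give a number beyond the scatter from that of compound 1.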